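This account rests on a few compounds, and the source may have more. Where it says the series, first, only, none or still open, it means among the compounds named here.

Compound 1 `COc1cc(OC)cc(-n2c(-c3ccccc3)nc(C)c2C)c1` gave 61%. Compound 2 `COc1ccc(-n2c(-c3ccc(F)cc3)nc(C)c2C)cc1` gave 41%.

In a functional assay, with a stated time of 15 min, tested at 100 uM (on this read-out lower numbers stand for a weaker effect and higher numbers for a stronger effect at the one concentration tested), compound 2 stands lowest of the two numbers, and compound 1 lies higher by a gap beyond the usual scatter. Compound 3 `COc1ccc(-n2c(-c3ccccc3)nc(C)c2C)cc1` has not yet been measured. It differs from compound 2 by hydrogen in place of fluoro on an aromatic carbon. Among the measured compounds shown here, no such step has been measured within this set, so its size is uncertain. The step of a number 9 percentage points higher from compound 2 to compound 3 (within the scatter) is expected to be a modest rise, possibly within the scatter. Compound 3 is expected to give 50%, within 30% to 70%.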

Compound 3, a percentage reported as activity, at one concentration (the size of the read-out at that concentration, not a potency): 59.6%
Compound 3: middle estimate off by 9.6 percentage points, on the low side; low and high end bracket the measured number.
By their numbers in this assay, from the lowest: compound 2; then compounds 3 and 1 (each within the scatter of the next).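

In this assay, the change from 4-fluorophenyl to phenyl gives a number 18.6 percentage points higher from compound 2 to compound 3 (beyond the scatter). Among the compounds shown here, this is the first change in a single place, and it shows that the read-out responds to fluoro versus hydrogen at this aromatic carbon, which the two earlier compounds, differing in more than one place, could not show. Nothing measured here gives a reason for the step. The compounds shown leave open how a chlorine, an amine or a carboxylic acid on this carbon would compare with hydrogen and fluoro. They also leave open whether the same step would hold with the two methoxy groups of compound 1.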